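Replacing the Carboxylic Acid with an Alcohol: Expected Solubility

This account rests on a few compounds, and the source may have more. Where it says the series, first, only, none or still open, it means among the compounds named here.

Three compounds sharing one core have been measured in a physicochemical assay for solubility, using the shake flask method, measured as kinetic solubility, at pH 7.4; on this read-out higher numbers stand for higher solubility and lower numbers for lower solubility:

compound 1 `O=C(O)c1cccc(-c2csc(Nc3ccccc3F)n2)c1` gives 80900 nM
compound 2 `O=C(O)c1cccc(-c2csc(Nc3ccc(F)cc3)n2)c1` gives 77700 nM
compound 3 `O=C(O)c1cccc(-c2csc(Nc3ccccc3)n2)c1` gives 70200 nM

Compound 1 sits close to its two neighbours: a 1.0-fold lower number from compound 1 to compound 2 (0.02 log units; within the scatter) and a 1.2-fold lower number from compound 1 to compound 3 (0.06 log units; within the scatter) are both within the scatter, as is a 1.1-fold lower number from compound 2 to compound 3 (0.04 log units; within the scatter). All three measured steps concern only a fluoro on the aniline ring, and none of them moved this assay beyond its noise.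

Compound 4 `OCc1cccc(-c2csc(Nc3ccccc3F)n2)c1` differs from compound 1 elsewhere: hydroxymethyl in place of carboxy on an aromatic carbon. Among the measured compounds shown here, no measured pair in this set touches the carboxy group, so there is no step here that bears directly on this change, and the measured steps give no guide to its size. The expectation therefore rests on the change itself rather than on an observed precedent, and carries wide uncertainty. The estimate is that compound 4 shows a lower number than compound 1, with a 4.0-fold lower number from compound 1 to compound 4 (0.61 log units; beyond the scatter), and that compound 4 comes out around 20000 nM, within a range from 4000 nM to 80000 nM.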

Compound 4, solubility: 30900 nM
Compound 4: middle estimate off by 1.5-fold (0.19 log units), on the low side; the range from low to high includes it.
By their numbers in this assay, from the lowest: compound 4; then compounds 3, 2 and 1 (each within the scatter of the next).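

Among the compounds shown here, this is the first change at the carboxy position, and in this assay it produces a clearer shift than any fluoro change seen so far: a 2.6-fold lower number from compound 1 to compound 4 (0.42 log units; beyond the scatter). Among compound 1, compound 2 and compound 3, the fluoro changes on the aniline ring all stayed within the scatter, so this aromatic carbon is the first place in the series where a single replacement moves the read-out measurably, although the step is only modest. The carboxy and hydroxymethyl groups each count one hydrogen-bond donor and one hydrogen-bond acceptor, so those counts do not separate the two groups, and nothing measured here accounts for the lower number.

Going by these compounds, it remains open whether the same replacement would give a step of similar size on the core of compound 2 or compound 3, since only the 2-fluorophenyl series shows it so far. On these data alone, how other groups on this aromatic carbon would compare also remains open, including a primary amide, a methyl ester, an amine or a longer chain ending in an alcohol.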